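A 2-Nitrophenyl Group Replaces 4-Fluorophenyl

A few compounds are considered here, and "the series" means these few. Any claim that something is new, unique, unknown or untested is made for them only; others in the source may bear on it.

Of the compounds shown here, three that share one core have been measured in a functional assay on B16-F10 cells (Mus musculus) for antiproliferative activity, read by MTT assay, with a stated time of 48 h; a higher number here means a weaker inhibitor, a lower number a stronger inhibitor. Compound 1 `CC(=O)N1N=C(c2ccc3ccccc3c2)OC1c1ccccc1` gives 2.57 ug/mL, compound 2 `CC(=O)N1N=C(c2ccc3ccccc3c2)OC1c1ccccc1F` gives 6.05 ug/mL, and compound 3 `CC(=O)N1N=C(c2ccc3ccccc3c2)OC1c1ccc(F)cc1` gives 4.65 ug/mL. Compound 3 cannot be separated from either of the others, as the two steps that reach it show: a 1.8-fold higher number from compound 1 to compound 3 (0.26 log units; within the scatter), and a 1.3-fold lower number from compound 2 to compound 3 (0.11 log units; within the scatter). Within the data shown here, only the step of a 2.4-fold higher number from compound 1 to compound 2 (0.37 log units; beyond the scatter) clears the scatter, and it is modest.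

The next compound, compound 4 `CC(=O)N1N=C(c2ccc3ccccc3c2)OC1c1ccccc1[N+](=O)[O-]`, has 2-nitrophenyl in place of 4-fluorophenyl on a saturated ring carbon. Among the measured compounds shown here, none of the measured compounds carries a nitro group, so no step speaks for this change directly. The closest evidence is the three small steps above, all among compounds that differ only in the phenyl group on that carbon. They suggest that changes there have so far moved the number only slightly, so no step beyond the scatter is expected. The estimated step is a 1.0-fold lower number from compound 3 to compound 4 (0.01 log units; within the scatter). With so little evidence for the new group, the range must stay wide. For compound 4 the expected value in this assay is 4.5 ug/mL, with an estimated range from 1.5 ug/mL to 14 ug/mL.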

Compound 4, half-maximal inhibitory concentration: 9.01 ug/mL
The estimate for compound 4 lay 2.0-fold (0.30 log units) below the measured number; measured number inside the range.
By their numbers in this assay, from the lowest: compounds 1, 3, 2 and 4 (each within the scatter of the next, the first and the last beyond it).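

In this assay, the nitro group gives the second step on this carbon that clears the scatter, a 3.5-fold higher number from compound 1 to compound 4 (0.54 log units; beyond the scatter), though the step is still modest; the first was the change from phenyl to 2-fluorophenyl. Compound 2 and compound 4, the two compounds with a group on the phenyl ring named with a 2, both stand apart from compound 1, while compound 3, with its 4-fluorophenyl, does not, yet the nitro compound cannot be separated from either fluoro compound, as a 1.9-fold higher number from compound 3 to compound 4 (0.29 log units; within the scatter) and a 1.5-fold higher number from compound 2 to compound 4 (0.17 log units; within the scatter) show. So on this evidence the swap of fluoro for the larger nitro group, with its two hydrogen-bond acceptors, brings no separable change, and nothing measured on these compounds explains the steps seen here.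

As far as these compounds go, whether the separation from compound 1 depends on where the group sits on the phenyl ring stays open, since only fluoro appears in both the 2 and the 4 form. It is also unknown how an amine or a methoxy group on that ring, or a cyclohexyl group in place of the whole phenyl ring, would read in this assay.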